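A Pyridine Ring Enters the Furan-Bearing Side Chain of Compound 2

The compounds below may be only part of what the source reports. "The series", "measured", "known", "first", "only" and "open" are said of these compounds alone.

Going by the values given here, in a functional assay on HCT-116 cells (Homo sapiens) for inhibition, with a stated time of 72 h (on this read-out higher numbers stand for weaker inhibition and lower numbers for stronger inhibition), only two compounds have numbers so far. Compound 1 (`NC1CCC(Nc2nc(NCc3ccc(-c4cccc(F)c4)cc3)c3ncn(C4CCCC4)c3n2)CC1`) gives 551 nM there. Compound 2 (`CC(C)(O)CNc1nc(NCc2ccc(-c3ccco3)cc2)c2ncn(C3CCCC3)c2n1`) gives 16700 nM there and so stands highest of the two, with a gap to compound 1 that lies beyond the usual scatter. These two compounds differ in more than one place, so their gap cannot be assigned to any single group.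

Compound 3 (`CC(C)(O)CNc1nc(NCc2ccc(-c3ccco3)nc2)c2ncn(C3CCCC3)c2n1`) has not yet been measured in this assay and differs from compound 2 in one place. The change (6-(furan-2-yl)pyridin-3-yl in place of 4-(furan-2-yl)phenyl on a saturated chain carbon bound to a nitrogen on an aromatic ring) is 6-(furan-2-yl)pyridin-3-yl in place of 4-(furan-2-yl)phenyl on a saturated chain carbon bound to a nitrogen on an aromatic ring. Among the compounds with values here, no measured pair shows a step of this kind, so the expectation rests only on how closely the two structures resemble each other. A small move toward stronger inhibition is expected, probably not beyond the scatter. The expected step is a 1.4-fold lower number from compound 2 to compound 3 (0.14 log units; within the scatter) on this estimate. For compound 3 the estimated value is 12000 nM with an expected range from 4000 nM to 35000 nM in this assay.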

Compound 3, half-maximal inhibitory concentration: 1270 nM
For compound 3 the middle estimate is 9.4-fold (0.98 log units) above the measured one; measured number below the stated range.
By their numbers in this assay, from the lowest: compound 1; then compound 3; then compound 2.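

Putting 6-(furan-2-yl)pyridin-3-yl in place of 4-(furan-2-yl)phenyl on a saturated chain carbon bound to a nitrogen on an aromatic ring gives a 13-fold lower number from compound 2 to compound 3 (1.12 log units; beyond the scatter) in this assay. The gap between compound 1 and compound 2 could be assigned to no single group, whereas this pair ties a large shift to this one place, and the exchange is a modest one on paper: both groups hold 11 heavy atoms, while the six-membered aromatic ring goes from carbon only to one with 1 hetero atom and the hydrogen-bond acceptors go from 1 to 2. No evidence at hand explains why the read-out moves this far.

Going by these compounds alone, a single pair cannot show whether the step would carry over to compounds with a different chain on the shared core, such as the one in compound 1. Nor do the compounds shown tell how a pyrimidine ring in place of the pyridine, or a thiophene in place of the furan, would compare with compound 3.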